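Benzofuranyl ethynyl variant: expectation for compound 4

A few compounds are considered here, and "the series" means these few. Any claim that something is new, unique, unknown or untested is made for them only; others in the source may bear on it.

Three compounds sharing one core differ only in the aryl group on the ethynyl arm. Compound 1 `CNC(=O)[C@@]12C[C@@H]1[C@@H](n1cnc3c(NC)nc(C#Cc4ccc(Cl)cc4)nc31)[C@H](O)[C@@H]2O` carries a chloro-substituted phenyl and in an assay on CHO cells for displacement of a labelled ligand from adenosine receptor A1 (Homo sapiens), read by scintillation counting, with a stated time of 60 min, tested at 10 uM (on this read-out lower numbers stand for less inhibition and higher numbers for more inhibition at the one concentration tested (going by the name of the read-out)), compound 1 gives 13%. Compound 2 `CNC(=O)[C@@]12C[C@@H]1[C@@H](n1cnc3c(NC)nc(C#Cc4ccc(OC)cc4)nc31)[C@H](O)[C@@H]2O`, with a methoxy-substituted phenyl, gives 10%. Compound 3 `CNC(=O)[C@@]12C[C@@H]1[C@@H](n1cnc3c(NC)nc(C#Cc4ccc(CO)cc4)nc31)[C@H](O)[C@@H]2O`, with a hydroxymethyl-substituted phenyl, gives 16%. Compound 2 stands at the lowest of the three numbers, but its gaps to compound 1 and to compound 3 are both within the scatter, so no order among the three can be read from these data.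

The steps seen are a number 3 percentage points lower from compound 1 to compound 2 (within the scatter), a number 3 percentage points higher from compound 1 to compound 3 (within the scatter) and a number 6 percentage points higher from compound 2 to compound 3 (within the scatter): every exchange of one ring substituent for another left the read-out essentially where it was.

Compound 4 `CNC(=O)[C@@]12C[C@@H]1[C@@H](n1cnc3c(NC)nc(C#Cc4cc5ccccc5o4)nc31)[C@H](O)[C@@H]2O` is not yet measured. Its change from compound 2 is 1-benzofuran-2-yl in place of 4-methoxyphenyl on a triple-bonded carbon. This is a larger change than any of the measured steps, which only swapped a single substituent on the phenyl ring, so none of them bears directly on a fused bicyclic replacing that ring. With every measured step within the scatter, the expectation for compound 4 is a step of a number 4 percentage points higher from compound 2 to compound 4 (within the scatter) that does not go beyond the scatter. Compound 4 is therefore estimated at 14%, within a range of 3% to 30%.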

Compound 4, a percentage reported as inhibition, at one concentration (the size of the read-out at that concentration, not a potency): 13%
The estimate for compound 4 lay 1 percentage points above the measured number; measured number inside the range.
By their numbers in this assay, from the lowest: compounds 2, 1, 4 and 3 (each within the scatter of the next).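

Exchanging the whole aryl group on the triple-bonded carbon, and not only a substituent on the phenyl ring, still leaves the read-out in this assay within the scatter for all three comparisons (a number 3 percentage points higher from compound 2 to compound 4 (within the scatter)) (a number 3 percentage points lower from compound 3 to compound 4 (within the scatter)) (no change at the digits printed from compound 1 to compound 4 (within the scatter)). The flat picture at this position therefore extends beyond substituent swaps on one phenyl ring to 1-benzofuran-2-yl, which adds a five-membered aromatic ring with 1 hetero atom to the six-membered aromatic ring of carbon only, so the four compounds cannot be told apart at the one concentration tested. No measurement at hand offers an explanation for this flat result.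

Every group on the ethynyl arm shown here is aromatic and uncharged, so it remains open whether an aminomethyl group or a carboxylic acid on the phenyl ring, or a longer chain in place of the aryl group, would move the read-out beyond the scatter. Also open, from the compounds shown here alone, is whether the four compounds differ in potency, as a single-concentration percentage at these low numbers gives no concentration-response information.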